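Swapping a Bromophenyl for an Aminophenyl on the Enone

This account rests on a few compounds, and the source may have more. Where it says the series, first, only, none or still open, it means among the compounds named here.

Compound 1 `O=C(/C=C/C1=Cc2ccccc2OC1)c1ccc(Cl)cc1` gives 56.1% in a functional assay on the whole organism for inhibition, with Mus musculus as the target, with a stated time of 1 h, at a dose of 30 mg/kg by the intraperitoneal route; on this read-out lower numbers stand for less inhibition and higher numbers for more inhibition at the one dose given (going by the name of the read-out).
Compound 2 `O=C(/C=C/C1=Cc2ccccc2OC1)c1ccc(Cl)cc1Cl` gives 53.3%.
Compound 3 `O=C(/C=C/C1=Cc2ccccc2OC1)c1cccc(Br)c1` gives 51.7%.

Compound 3 has the lowest of the three numbers, yet its gaps to compound 2 and to compound 1 are both within the scatter, so no ranking can be drawn from them. Compound 4 `Nc1ccc(C(=O)/C=C/C2=Cc3ccccc3OC2)cc1` differs from compound 3 in one place: 4-aminophenyl in place of 3-bromophenyl on a carbonyl carbon. Two measured steps in the same region bear on this: a number 4.4 percentage points lower from compound 1 to compound 3 (within the scatter) and a number 2.8 percentage points lower from compound 1 to compound 2 (within the scatter), both within the scatter. The 4-aminophenyl group has not been tried, so the step of a number 1.7 percentage points lower from compound 3 to compound 4 (within the scatter) is expected to stay within the scatter in this assay, with a wide range to reflect the untested group. Compound 4 is therefore estimated at 50%, between 30% and 70%.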

Compound 4, a percentage reported as inhibition, in the whole organism at one dose (the size of the read-out at that dose, not a potency): 52.6%
For compound 4 the middle estimate is 2.6 percentage points below the measured one; low and high end bracket the measured number.
By their numbers in this assay, from the lowest: compounds 3, 4, 2 and 1 (each within the scatter of the next).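

Compound 1, compound 2 and compound 3 carry only halogens on this phenyl ring, so the amino group is a new kind of substituent here. In this assay, 4-aminophenyl in place of 3-bromophenyl on the carbonyl carbon gives a number 0.9 percentage points higher from compound 3 to compound 4 (within the scatter), and amino in place of chloro gives a number 3.5 percentage points lower from compound 1 to compound 4 (within the scatter). This position therefore accepts a group with a hydrogen-bond donor, without a step beyond the scatter.

From the compounds shown here alone, whether a carboxylic acid or a methoxy group on this ring would also stay within the scatter remains open. No evidence is available on what lies behind these numbers.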